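Chloro for methoxy on the aryl group of compound 2

The source may report more compounds than this note shows. Statements on the series, on what has been measured and on what is new or still open speak of the compounds shown alone.

Compound 2 `COc1ccc(-c2cn(-c3cccc(C(=O)/C=C/c4ccc(O)c(OC)c4)c3)c(=O)[nH]2)cc1` gives 3180 nM in a functional assay on MCF7 cells (Homo sapiens) for inhibition (on this read-out lower numbers stand for stronger inhibition of growth and higher numbers for weaker inhibition of growth), the highest of the two numbers at hand; the nearest, compound 1 `O=C(/C=C/c1cccc(O)c1)c1cccc(-n2cc(-c3ccc(Cl)cc3)[nH]c2=O)c1`, gives 1270 nM in this assay, a gap beyond the scatter. Compound 3 `COc1cc(/C=C/C(=O)c2cccc(-n3cc(-c4ccc(Cl)cc4)[nH]c3=O)c2)ccc1O` keeps the rest of compound 2 and changes one group: chloro in place of methoxy on an aromatic carbon; read one bond further out, 4-methoxyphenyl to 4-chlorophenyl. For the measured compounds named here, no measured pair shows this exchange alone, so the step expected in this assay, a 1.6-fold lower number from compound 2 to compound 3 (0.20 log units; within the scatter), is a modest gain that may only just exceed the scatter. Compound 3 is therefore estimated at 2000 nM, range 900 nM to 4500 nM.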

Compound 3, concentration for 50% growth inhibition: 2300 nM
Compound 3: the middle estimate sits 1.2-fold (0.06 log units) below what was measured; the range from low to high includes it.
By their numbers in this assay, from the lowest: compounds 1, 3 and 2 (each within the scatter of the next, the first and the last beyond it).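

In this assay chloro in place of methoxy on an aromatic carbon, para to a large group, gives a 1.4-fold lower number from compound 2 to compound 3 (0.14 log units; within the scatter) and so does not separate the two groups at this position. 4-Hydroxy-3-methoxyphenyl in place of 3-hydroxyphenyl on the double-bonded chain carbon gives a 1.8-fold higher number from compound 1 to compound 3 (0.26 log units; within the scatter) and does not separate those two groups either. Nothing at hand speaks to the cause of either step.

Still open, from the compounds shown here alone, is whether an amine or a carboxylic acid at the para position of this aryl group would give a step beyond the scatter.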